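The source may report more compounds than this note shows. Statements on the series, on what has been measured and on what is new or still open speak of the compounds shown alone.

In an ADME assay on NIH3T3 cells (Mus musculus) for cytotoxicity, read by MTT assay, with a stated time of 24 h (on this read-out lower numbers stand for stronger inhibition and higher numbers for weaker inhibition), compound 1 `Cn1nnnc1SCC(=O)N/N=c1/scc(-c2ccccc2)n1-c1ccccc1` gives 173 ug/mL.
Compound 2 `Cc1ccc(-c2cs/c(=N/NC(=O)CSc3ncccn3)n2-c2ccccc2)cc1` reaches only a limit of the assay, > 500 ug/mL, not a number.
Compound 3 `Cn1nnnc1SCC(=O)N/N=c1/scc(-c2ccc(C#N)cc2)n1-c1ccccc1` gives 213 ug/mL.

Compound 3 holds the higher of the two numbers, yet the step of a 1.2-fold higher number from compound 1 to compound 3 (0.09 log units; within the scatter) stays within the scatter. Compound 4 `Cc1ccc(-c2cs/c(=N/NC(=O)CSc3nnnn3C)n2-c2ccccc2)cc1` differs from compound 3 by methyl in place of cyano on an aromatic carbon. For the measured compounds named here, no measured step swaps methyl for cyano at this place; the only measured step, a 1.2-fold higher number from compound 1 to compound 3 (0.09 log units; within the scatter), exchanged hydrogen for cyano without leaving the scatter. Compound 2, which carries the same 4-methylphenyl as compound 4 though differing elsewhere, reached only the limit (the limit of > 500 ug/mL in this assay, at which 1 of the 3 values shown sits). I therefore expect a modest rise, a 1.2-fold higher number from compound 3 to compound 4 (0.09 log units; within the scatter), of uncertain size. Compound 4 is estimated at 260 ug/mL, between 140 ug/mL and 500 ug/mL.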

Compound 4, half-maximal inhibitory concentration: 243 ug/mL
Compound 4: middle estimate off by 1.1-fold (0.03 log units), on the high side; measured number inside the range.
By their numbers in this assay, from the lowest: compounds 1, 3 and 4 (each within the scatter of the next). At a limit, above all of these: compound 2.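

In this assay, the place on the six-membered aromatic ring para to a large group tolerates methyl as it does cyano or hydrogen: the change gives a 1.1-fold higher number from compound 3 to compound 4 (0.06 log units; within the scatter), and also a 1.4-fold higher number from compound 1 to compound 4 (0.15 log units; within the scatter). The group on the sulfur matters more, as 1-methyl-1H-tetrazol-5-yl in place of pyrimidin-2-yl gives an at least 2.0-fold lower number from compound 2 to compound 4 (0.31 log units; beyond the scatter). That step has only a lower bound, since compound 2 gives a limit and not a number: the limit of > 500 ug/mL in this assay, at which 1 of the 4 values shown sits.

Going by these compounds, whether an amine or a carboxylic acid at the same ring place would shift the number remains open. So does the true size of the step on the sulfur.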